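Oxolan-3-yl in place of cyclopropylmethyl on an amide-type nitrogen

This account rests on a few compounds, and the source may have more. Where it says the series, first, only, none or still open, it means among the compounds named here.

Compound 1 `COc1ccc(C(=O)N(Cc2c[nH]c(-c3ccccc3)n2)C2CCCCC2)cc1` gives 2.9
Compound 2 `O=C(CN(CC1CC1)C(=O)c1ccc(-c2ccccn2)cc1)Nc1cc(F)cc(F)c1` gives 3.1

Both numbers come from a physicochemical assay for lipophilicity (on this read-out lower numbers stand for lower lipophilicity and higher numbers for higher lipophilicity), and lie within the usual scatter of each other, so compound 2 cannot be ranked against compound 1. Compound 3 `O=C(CN(C(=O)c1ccc(-c2ccccn2)cc1)C1CCOC1)Nc1cc(F)cc(F)c1` carries oxolan-3-yl in place of cyclopropylmethyl on an amide-type nitrogen. For the measured compounds named here, no two measured compounds differ in one place, so nothing here sizes this swap directly. Compound 2 at 3.1 is the starting point for the expectation. In this assay a fall beyond the scatter is expected, estimated as a number 0.80 log units lower from compound 2 to compound 3 (beyond the scatter) on the structural change alone. For compound 3 the expected value is 2.3 with an estimated range from 1.9 to 2.7 around it.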

Compound 3, distribution coefficient: 2.5
Estimate against measurement, compound 3: 0.20 log units below, within the range that was stated.
By their numbers in this assay, from the lowest: compound 3; then compounds 1 and 2 (each within the scatter of the next).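

For the compounds shown here, this gives the first direct reading of a single change at this amide-type nitrogen: in this assay, oxolan-3-yl in place of cyclopropylmethyl gives a number 0.60 log units lower from compound 2 to compound 3 (beyond the scatter), a modest step. The entering group has a ring oxygen and a hydrogen-bond acceptor, and the leaving group has neither. No measurement at hand shows what accounts for the step.

As far as these compounds go, how a ring amine such as pyrrolidin-3-yl, or a carboxylic acid on a short chain, would read at this nitrogen stays open. So does whether this swap gives a similar step on another core.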